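The source may report more compounds than this note shows. Statements on the series, on what has been measured and on what is new or still open speak of the compounds shown alone.

In a functional assay on HeLa cells (Homo sapiens) for antiproliferative activity, read by sulforhodamine B assay, with a stated time of 72 h (a lower number here means a stronger inhibitor, a higher number a weaker inhibitor), the measured compounds are:

Compound 1 `COc1ccccc1NC(=S)N/N=C/c1ccc2ccccc2n1` gives > 100000 nM (a limit)
Compound 2 `Cc1ccc(NC(=S)N/N=C/c2ccc3ccccc3n2)cc1` gives 86000 nM (a number)
Compound 3 `S=C(N/N=C/c1ccc2ccccc2n1)Nc1ccc(Cl)cc1` gives > 100000 nM (a limit)

Compound 3 reads > 100000 nM as a limit and not a number, so it stands at the limit of > 100000 nM in this assay, at which 2 of the 3 values shown sit, and no exact place can be given. Compound 4 `S=C(N/N=C/c1ccc2ccccc2n1)Nc1ccccc1` carries one change: hydrogen in place of chloro on an aromatic carbon (4-chlorophenyl to phenyl). The closest measured change, on that same ring carbon, is an at least 1.1-fold higher number from compound 2 to compound 3 (0.06 log units; that floor lies within the scatter) and swapping the ring group gave an at least 1.1-fold lower number from compound 1 to compound 2 (0.06 log units; that floor lies within the scatter) while the remaining comparison is a step that the two limits leave unreadable from compound 1 to compound 3 (no size to read). None of these shows a step beyond the scatter, so none is expected here in this assay either. The expected step is an at least 1.1-fold lower number from compound 3 to compound 4 (0.04 log units; that floor lies within the scatter) and another reading at the limit is quite possible. For compound 4 the estimated value is 90000 nM with an expected range from 40000 nM to 200000 nM in this assay.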

Compound 4, half-maximal inhibitory concentration: 27400 nM
For compound 4 the middle estimate is 3.3-fold (0.52 log units) above the measured one; the measured number lies below the stated range.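

Hydrogen on this ring carbon is the first change to give a step beyond the scatter in this assay: chloro to hydrogen gives an at least 3.6-fold lower number from compound 3 to compound 4 (0.56 log units; beyond the scatter), and methyl to hydrogen gives a 3.1-fold lower number from compound 2 to compound 4 (0.50 log units; beyond the scatter). Hydrogen in place of methoxy gives an at least 3.6-fold lower number from compound 1 to compound 4 (0.56 log units; beyond the scatter), so the unsubstituted phenyl of compound 4 beats all three substituted rings. Compound 1 and compound 3 are limits and not numbers: the limit of > 100000 nM in this assay, at which 2 of the 4 values shown sit.

Going by these compounds, whether fluoro, an amine or a carboxylic acid on this ring carbon would match hydrogen stays open. These compounds also do not tell what lies behind the step.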